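Hydroxy Added to a Pair at the Assay Limit

The source may hold more compounds than are shown below. What is called first, only, known or untested is meant among the compounds shown, and "the series" means these compounds.

Compound 2 `COC1=CC(=O)[C@@]2(c3cc(=O)c4ccc(O)cc4o3)[C@H](CC=C(C)[C@@H]2C[C@]2(C)[C@@H](C(=O)O)CC=C3[C@H]2CCCC3(C)C)C1=O` was tested in a functional assay on HepG2 cells (Homo sapiens) for antiproliferative activity, read by sulforhodamine B assay, with a stated time of 72 h; a lower number here means a stronger inhibitor of growth, a higher number a weaker inhibitor of growth. Compound 2 gives > 10000 nM, which is a limit of this assay and not a number. Compound 1 `COC1=CC(=O)[C@@]2(c3cc(=O)c4c(O)cc(O)cc4o3)[C@H](C[C@]3(C)[C@@H](C(=O)O)CC=C4[C@H]3CCCC4(C)C)C(C)=CC[C@H]2C1=O` likewise gives > 10000 nM in this assay, again a limit. Compound 2 therefore sits where the only other measured compound sits, as shown by the limit of > 10000 nM in this assay, at which 2 of the 2 values shown sit. Compound 3 `COC1=CC(=O)[C@@]2(c3cc(=O)c4c(O)cc(O)cc4o3)[C@H](CC=C(C)[C@@H]2C[C@]2(C)[C@@H](C(=O)O)CC=C3[C@H]2CCCC3(C)C)C1=O` differs from compound 2 by hydroxy in place of hydrogen on an aromatic carbon. Among the measured compounds shown here, no step between measured compounds is on record, so the expected step that the limit leaves unreadable from compound 2 to compound 3 in this assay is none beyond the scatter. Compound 3 is estimated at 20000 nM, with a range from 5000 nM to 100000 nM.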

Compound 3, concentration for 50% growth inhibition: > 10000 nM
Compound 3 ended at the assay's limit; the forecaster's own chance of this, stated with the estimate: 90%; the middle value is on the limit's open side.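

Neither the step from compound 2 to compound 3 nor the step from compound 1 to compound 3 can be read, since the values are limits and not numbers: the limit of > 10000 nM in this assay, at which 3 of the 3 values shown sit.

On these data alone, whether hydroxy in place of hydrogen or the configuration as drawn alters growth inhibition stays open.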